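Swapping a Pyrimidine for a Methylphenyl on the Pyrazole Core

A few compounds are considered here, and "the series" means these few. Any claim that something is new, unique, unknown or untested is made for them only; others in the source may bear on it.

Of the compounds shown here, two from this series have been tested in a functional assay on BJAB cells (Homo sapiens) for antiproliferative activity, with a stated time of 4 days; a higher number here means that more compound is needed for the effect, a lower number that less compound is needed. Compound 1, with the structure `Cc1nn(-c2nc(-c3ccc(Cl)c(Cl)c3)c(SC(C)C)s2)c(C(=O)O)c1-c1cncnc1`, gives 22000 nM in this assay. Compound 2, with the structure `Cc1c(-c2cc(Cl)cc(Cl)c2)c(C(=O)O)nn1-c1nc(-c2cc(Cl)cc(Cl)c2)c(SC(C)C)s1`, gives 2000 nM in this assay. Among these two numbers compound 1 stands highest: the value of compound 2 is a lower one, by a gap that lies beyond the usual scatter, so compound 1 needs clearly more compound for the same effect.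

Compound 3, with the structure `Cc1ccc(-c2c(C)nn(-c3nc(-c4ccc(Cl)c(Cl)c4)c(SC(C)C)s3)c2C(=O)O)cc1`, has not yet been measured. It differs from compound 1 in one place: 4-methylphenyl in place of pyrimidin-5-yl on an aromatic carbon. The shared core and the rest of the molecule stay the same.

Among the compounds with values here, since no measured pair isolates exactly this change, the expectation rests on the spread seen between compound 1 and compound 2. Compound 3 is expected to give a lower number than compound 1, with a step of a 4.4-fold lower number from compound 1 to compound 3 (0.64 log units; beyond the scatter) in this assay. The estimate for compound 3 is 5000 nM, with a plausible range from 1500 nM to 15000 nM.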

Compound 3, half-maximal effective concentration: 3800 nM
The estimate for compound 3 lay 1.3-fold (0.12 log units) above the measured number; measured number inside the range.
By their numbers in this assay, from the lowest: compounds 2 and 3 (each within the scatter of the next); then compound 1.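

In this assay the pair of compound 1 and compound 3 gives a direct reading at this aromatic carbon, with the rest of the molecule held the same: the swap gives a 5.8-fold lower number from compound 1 to compound 3 (0.76 log units; beyond the scatter) in a single change. This shows that the number responds to the group at this place, and that here the all-carbon 4-methylphenyl ring goes with the lower number, while pyrimidin-5-yl, with its two hydrogen-bond acceptors, goes with the higher one. No measurement at hand gives a reason for this step.

The compounds shown leave open which part of the swap carries the step, the loss of the two ring nitrogens or the gain of the methyl group, and a plain phenyl ring at this place would separate the two. Also open, going by these compounds, is how the number would respond to a ring with a different group in the place of that methyl, such as 4-aminophenyl or 4-methoxyphenyl, and whether either would move it further in the same direction.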